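The source may report more compounds than this note shows. Statements on the series, on what has been measured and on what is new or still open speak of the compounds shown alone.

Compound 1 `COC(=O)c1sc2cc(-c3ccc(-c4cccs4)s3)cnc2c1N`: 1000 nM
Compound 2 `COC(=O)c1sc2cc(-c3ccoc3)cnc2c1N`: > 120000 nM
Compound 3 `COC(=O)c1sc2cc(-c3ccc(OC)cc3)cnc2c1N`: > 150000 nM

Of the compounds shown here, three sharing one core have so far been tested in a functional assay on MCF7 cells (Homo sapiens) for inhibition, read by sulforhodamine B assay, with a stated time of 48 h; on this read-out higher numbers stand for weaker inhibition of growth and lower numbers for stronger inhibition of growth. Compound 1 gives 1000 nM. For compound 2 the assay reports only a limit, > 120000 nM, that is the limit of > 120000 nM in this assay, at which 1 of the 3 values shown sits. For compound 3 the assay likewise reports only a limit, > 150000 nM, that is the limit of > 150000 nM in this assay, at which 1 of the 3 values shown sits. Compound 2 thus stands at a limit rather than at a number, and of the other two values one is a limit as well; only compound 1 carries a measured number, and the gap from it to the limit of compound 2 is wide.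

Compound 4 `COC(=O)c1sc2cc(-c3ccccc3N)cnc2c1N` has not yet been measured. It differs from compound 2 in one place: 2-aminophenyl in place of furan-3-yl on an aromatic carbon. Among the measured compounds shown here, no pair of measured compounds follows this same change, so the size of the step cannot be read from a measured step. Since compound 2 sits at a limit and compound 3 sits at a limit too, the expectation is for a step small or none beyond the scatter, with any movement more likely toward stronger inhibition than weaker. Compound 4 is therefore expected to give about 60000 nM, within a range from 15000 nM to 200000 nM. The expected step from compound 2 to compound 4 is an at least 2.0-fold lower number from compound 2 to compound 4 (0.30 log units; that floor lies within the scatter).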

Compound 4, concentration for 50% growth inhibition: 4200 nM
Beside the measured number, compound 4's estimate is 14-fold (1.15 log units) above it; measured number below the stated range.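

In this assay, the place two atoms from the ring nitrogen turns out to give a measured number with a single aromatic ring, not only with the larger group of compound 1, as 2-aminophenyl in place of furan-3-yl brings an at least 28-fold lower number from compound 2 to compound 4 (1.45 log units; beyond the scatter). Compound 2 stands at a limit, so this step has a floor but no measured end: the limit of > 120000 nM in this assay, at which 1 of the 4 values shown sits. A six-membered aromatic ring of carbon only is not enough by itself, since compound 3 carries one at this place and also stands at a limit: the limit of > 150000 nM in this assay, at which 1 of the 4 values shown sits.

From the compounds shown here alone, what remains open is whether the amine itself accounts for the step, a question that a plain phenyl group, or a phenyl ring with a hydroxyl or an aminomethyl group in place of the amine, would help to settle. Going by these compounds, it is also open whether an amine would act in the same way on a five-membered aromatic ring such as furan-3-yl, or on the larger group of compound 1.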